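Unresolved stereochemistry of compound 2 in the cytotoxicity read-out

A few compounds are considered here, and "the series" means these few. Any claim that something is new, unique, unknown or untested is made for them only; others in the source may bear on it.

Compound 2 `Clc1ccc2c(NC[C@@H]3CCCN4CCCC[C@H]34)ccnc2c1` gives 22600 nM in an ADME assay on HDF cells (Homo sapiens) for cytotoxicity, read by MTT assay, with a stated time of 72 h; on this read-out higher numbers stand for weaker inhibition and lower numbers for stronger inhibition. Compound 1 `Clc1ccc2c(NC[C@H]3CCCN4CCCC[C@@H]34)ccnc2c1` gives 26900 nM in this assay, and the step of a 1.2-fold lower number from compound 1 to compound 2 (0.08 log units; within the scatter) is within the scatter, so compound 2 stands alongside compound 1 rather than apart from it. Compound 3 `Clc1ccc2c(NCC3CCCN4CCCCC34)ccnc2c1` differs from compound 2 in this way: the two compounds have the same atoms and bonds; at least one stereo element is drawn with a configuration in one of them and without one in the other: 2 of 2 stereo elements differ; a stereocentre at a saturated ring carbon is drawn S in compound 2 and without a configuration in compound 3; a stereocentre at a saturated ring carbon is drawn R in compound 2 and without a configuration in compound 3. Among the measured compounds shown here, the only measured step that bears on this is the one from compound 1 to compound 2, since (the fact that compounds 1 and 2 differ only in the configuration as drawn), and it was small. Compound 3 is therefore expected to show no step beyond the scatter, an estimated 1.1-fold higher number from compound 2 to compound 3 (0.04 log units; within the scatter). The estimate for compound 3 is 24500 nM, expected between 15000 nM and 40000 nM.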

Compound 3, half-maximal inhibitory concentration: 24600 nM
Compound 3: the middle estimate sits 1.0-fold (0.00 log units) below what was measured; measured number inside the range.
By their numbers in this assay, from the lowest: compounds 2, 3 and 1 (each within the scatter of the next).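

In this assay, compound 3, drawn without configuration, sits level with both mirror-image forms: a 1.1-fold higher number from compound 2 to compound 3 (0.04 log units; within the scatter) and a 1.1-fold lower number from compound 1 to compound 3 (0.04 log units; within the scatter). Across these three compounds, the read-out therefore separates no form at the two stereocentres. This comparison rests on a single structural difference: the fact that one of compounds 2 and 3 is drawn with a defined configuration and the other without, at the place where they differ

Still open, going by these compounds, is whether this holds when the chlorine on the shared core is replaced by a trifluoromethyl group, or when the link to the core is a longer chain. The compounds shown also do not tell which stereoisomers compound 3 contains.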